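Trimming a Methyl From the Aryl Ring of Compound 3

The source may hold more compounds than are shown below. What is called first, only, known or untested is meant among the compounds shown, and "the series" means these compounds.

In a functional assay on BJAB cells (Homo sapiens) for antiproliferative activity, with a stated time of 4 days (a lower number here means that less compound is needed, a higher number that more compound is needed for the effect), three analogues sharing one core have been measured. Compound 1 `Cc1nn(-c2nc(-c3ccc(Cl)c(Cl)c3)c(SC(C)C)s2)c(C(=O)O)c1-c1cnn(C)c1` gives 6800 nM, compound 2 `Cc1cc(C#N)cc(-c2c(C)nn(-c3nc(-c4ccc(Cl)c(Cl)c4)c(SC(C)C)s3)c2C(=O)O)c1` gives 4800 nM, and compound 3 `Cc1cccc(-c2c(C)nn(-c3nc(-c4ccc(Cl)c(Cl)c4)c(SC(C)C)s3)c2C(=O)O)c1` gives 17000 nM. Compound 3 stands highest of the three: the step of a 2.5-fold higher number from compound 1 to compound 3 (0.40 log units; beyond the scatter) and the step of a 3.5-fold higher number from compound 2 to compound 3 (0.55 log units; beyond the scatter) both lie beyond the scatter, while a 1.4-fold lower number from compound 1 to compound 2 (0.15 log units; within the scatter) does not.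

Compound 4 `Cc1nn(-c2nc(-c3ccc(Cl)c(Cl)c3)c(SC(C)C)s2)c(C(=O)O)c1-c1ccccc1` is the next case. It differs from compound 3 in one place: hydrogen in place of methyl on an aromatic carbon. Within the data shown here, none of the measured steps removes a methyl; the only step that strips a group from this ring, a 3.5-fold higher number from compound 2 to compound 3 (0.55 log units; beyond the scatter), concerns a nitrile, not a methyl, so it bears on the question only loosely. Among the measured compounds shown here, with no direct precedent, the expected change from compound 3 to compound 4 in this assay is small, no change at the digits printed from compound 3 to compound 4 (within the scatter), and not beyond the scatter in either direction. Compound 4 is therefore estimated at 17000 nM, within a range of 7000 nM to 40000 nM.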

Compound 4, half-maximal effective concentration: 3000 nM
Beside the measured number, compound 4's estimate is 5.7-fold (0.75 log units) above it, and the stated range ends above it.
By their numbers in this assay, from the lowest: compounds 4, 2 and 1 (each within the scatter of the next, the first and the last beyond it); then compound 3.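

Cutting 3-methylphenyl back to phenyl gives a 5.7-fold lower number from compound 3 to compound 4 (0.75 log units; beyond the scatter) in this assay and so shows that, at this place on the six-membered aromatic ring, a single methyl separates two results beyond the scatter, which no earlier step had tested. The methyl does not set this level on its own, since compound 2 carries it alongside a nitrile and yet a 1.6-fold lower number from compound 2 to compound 4 (0.20 log units; within the scatter) stays within the scatter, whereas a 2.3-fold lower number from compound 1 to compound 4 (0.36 log units; beyond the scatter) shows that phenyl also stands apart from the 1-methyl-1H-pyrazol-4-yl group of compound 1. Nothing available accounts for the size of the methyl step.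

On these data alone, whether a methoxy group, a chlorine or an amine at this same place would behave like the methyl stays open. So does the result of a phenyl carrying the nitrile alone, without the methyl.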